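Methylating the Ring Nitrogen of a Weak Aortic Inhibitor

The source may report more compounds than this note shows. Statements on the series, on what has been measured and on what is new or still open speak of the compounds shown alone.

Going by the values given here, compound 1 `CC(C)(C)[Si](OCc1ccc(=O)[nH]n1)(c1ccccc1)c1ccccc1` gives 62600 nM in a functional assay on aorta (Rattus norvegicus) (a higher number here means a weaker inhibitor, a lower number a stronger inhibitor), and it is the only compound here to yield a number rather than a limit. Compound 2 `Cn1nc(CCOCc2ccccc2)ccc1=O` reaches only the limit of > 100000 nM in this assay. Compound 3 `Cn1nc(CCCO)ccc1=O` likewise stops at the limit of > 100000 nM in this assay. Two of the values shown therefore sit at the limit of > 100000 nM in this assay, at which 2 of the 3 values shown sit, and only compound 1 falls inside the measurable range.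

Compound 4 `Cn1nc(CO[Si](c2ccccc2)(c2ccccc2)C(C)(C)C)ccc1=O` differs from compound 1 by methyl in place of hydrogen on an aromatic nitrogen, a methyl in place of hydrogen on an aromatic nitrogen. Among the compounds with values here, no measured pair shows this change, so the expected step is set against the limit: a weakening beyond the scatter is expected for compound 4, a 1.6-fold higher number from compound 1 to compound 4 (0.20 log units; within the scatter). Compound 4 is thus estimated at 100000 nM, from 40000 nM to 250000 nM.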

Compound 4, half-maximal inhibitory concentration: 58400 nM
The estimate for compound 4 lay 1.7-fold (0.23 log units) above the measured number; low and high end bracket the measured number.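

In this assay, methyl in place of hydrogen on an aromatic nitrogen gives a 1.1-fold lower number from compound 1 to compound 4 (0.03 log units; within the scatter), so the hydrogen at this position can be replaced by methyl with no step beyond the scatter. Compound 4 thus stays in the measurable range with compound 1, while compound 2 and compound 3 stand at a limit of the assay: the limit of > 100000 nM in this assay, at which 2 of the 4 values shown sit. As far as these compounds go, it remains open whether ethyl or benzyl on this nitrogen would also leave the number in place. From the compounds shown here alone, it also remains open whether an amine or a carboxylic acid in place of the tert-butyldiphenylsilyl group would give a measurable number.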